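The source may report more compounds than this note shows. Statements on the series, on what has been measured and on what is new or still open speak of the compounds shown alone.

Of the compounds shown here, three sharing one core have been measured in a physicochemical assay for lipophilicity, measured as octanol-water partition; a lower number here means a more polar compound, a higher number a more lipophilic compound. Compound 1 `C/C(=N\NC(=O)COc1cccc2ccccc12)c1ccc(C#N)cc1Br` gives 3.61, the lowest of the three; compound 2 `O=C(COc1cccc2ccccc12)N/N=C/c1ccccc1O` gives 3.73, within the scatter of compound 1, and compound 3 `O=C(COc1cccc2ccccc12)N/N=C/c1ccc(Br)cc1` gives 4.81, far above both. Among the compounds with values here, the only single change measured is on the carbon with a double bond to nitrogen: a number 1.08 log units higher from compound 2 to compound 3 (beyond the scatter), a step in which a hydroxyl left and a bromine entered. Compound 4 `C/C(=N\NC(=O)COc1cccc2ccccc12)c1cccc([N+](=O)[O-])c1` differs from compound 1 at the same place: 3-nitrophenyl in place of 2-bromo-4-cyanophenyl on a carbon with a double bond to nitrogen. Since that measured step was large and a bromine now leaves, a downward step of a number 0.51 log units lower from compound 1 to compound 4 (beyond the scatter) is expected. Compound 4 is estimated at 3.1, between 2.6 and 3.6.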

Compound 4, partition coefficient: 3.37
Compound 4: middle estimate off by 0.27 log units, on the low side; low and high end bracket the measured number.
By their numbers in this assay, from the lowest: compounds 4, 1 and 2 (each within the scatter of the next, the first and the last beyond it); then compound 3.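

At the carbon with a double bond to nitrogen, a bromine can leave without a large shift: in this assay the result is a number 0.24 log units lower from compound 1 to compound 4 (within the scatter) when 3-nitrophenyl replaces 2-bromo-4-cyanophenyl. The earlier result, a number 1.08 log units higher from compound 2 to compound 3 (beyond the scatter) when a bromine entered, therefore holds for that pair and is no general measure for this place. Nothing measured here explains the different sizes of the two steps. Still open, on these data alone, is what the bromine, the nitrile and the nitro group each contribute alone, and where an amine or a carboxylic acid at this place would fall.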